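The source may report more compounds than this note shows. Statements on the series, on what has been measured and on what is new or still open speak of the compounds shown alone.

Values in a toxicity assay on SNB-19 cells (Homo sapiens) for cytotoxicity, with a stated time of 24 h; on this read-out higher numbers stand for lower toxicity in this test and lower numbers for higher toxicity in this test:
- compound 1 `C=C1CC[C@@H]2[C@](C)(CO)[C@H](O)CC[C@@]2(C)[C@@H]1C/C=C1/C(=O)OC[C@H]1Oc1c(Cl)cc(Cl)c2cccnc12`: 85200 nM
- compound 2 `C=C1CC[C@@H]2[C@](C)(CO)[C@H](O)CC[C@@]2(C)[C@@H]1C/C=C1/C(=O)OC[C@@H]1Oc1cccc2ccc(C)nc12`: > 100000 nM (a limit of the assay, not a number)
- compound 3 `C=C1CC[C@@H]2[C@](C)(CO)[C@H](O)CC[C@@]2(C)[C@@H]1C/C=C1/C(=O)OC[C@@H]1Oc1cccc2cccnc12`: 22700 nM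

Compound 3 gives the lowest number in this assay, at 22700 nM. Compound 1 stands higher, at 85200 nM. The entry for compound 2 is only a limit, > 100000 nM.

The next step leads to compound 4 `C=C1CC[C@@H]2[C@](C)(CO)[C@H](O)CC[C@@]2(C)[C@@H]1C/C=C1/C(=O)OC[C@@H]1Oc1c(Cl)cc(Cl)c2cccnc12`. The change is 5,7-dichloroquinolin-8-yl in place of quinolin-8-yl on an oxygen on a saturated carbon. Among the compounds with values here, only one measured step bears on it, and only indirectly: an at least 4.4-fold lower number from compound 2 to compound 3 (0.64 log units; beyond the scatter), with hydrogen in place of methyl on an aromatic carbon. That step involves a different group, but it shows that a small change on an aromatic carbon can move the number beyond the scatter. Compound 1 carries the same 5,7-dichloroquinolin-8-yl group and gives 85200 nM, which points upward. A modest rise is therefore expected, meaning lower toxicity in this test. The estimated step is a 2.0-fold higher number from compound 3 to compound 4 (0.30 log units; within the scatter). For compound 4 the estimated value is 45000 nM, with an expected range of 15000 nM to 95000 nM.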

Compound 4, half-maximal cytotoxic concentration: > 100000 nM
Compound 4 was reported as a limit (the forecaster's own chance of this, stated with the estimate: 15%); at least 2.2-fold (0.34 log units) between middle value and limit.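

Replacing quinolin-8-yl with 5,7-dichloroquinolin-8-yl on an oxygen on a saturated carbon now has a direct reading in this assay, with the drawn configuration of the saturated ring carbon held: an at least 4.4-fold higher number from compound 3 to compound 4 (0.64 log units; beyond the scatter). Compound 4 gives > 100000 nM, which is a limit of the assay and not a number, and the step between compound 2 and compound 4 cannot be read: the limit of > 100000 nM in this assay, at which 2 of the 4 values shown sit. With 5,7-dichloroquinolin-8-yl held, the pair differing at the saturated ring carbon gives an at least 1.1-fold higher number from compound 1 to compound 4 (0.06 log units; that floor lies within the scatter), so these values establish no effect of configuration for this pair: the fact that compounds 1 and 4 differ only in the configuration as drawn.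

From the compounds shown here alone, the full size of the change from quinolin-8-yl remains open, as does whether it needs both chlorines or one alone. Also open, going by these compounds, is how an amine or a carboxylic acid on the quinolin-8-yl group would read in this assay.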